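A few compounds are considered here, and "the series" means these few. Any claim that something is new, unique, unknown or untested is made for them only; others in the source may bear on it.

Measured so far:
Compound 1 `O=C(Nc1ccc(Cl)c(-c2nnc3c(Cl)cccn23)c1)c1ccc(C(F)(F)F)cc1F` — > 100000 nM
Compound 2 `O=C(Nc1ccc(Cl)c(-c2nnc3c(Cl)cccn23)c1)c1ccccc1` — 73500 nM
Compound 3 `O=C(Nc1ccc(Cl)c(-c2nnc3c(Cl)cccn23)c1)c1ccccc1Cl` — > 100000 nM

In a functional assay on U-251 cells (Homo sapiens) for antiproliferative activity, read by MTT assay, with a stated time of 72 h (on this read-out higher numbers stand for weaker inhibition and lower numbers for stronger inhibition), compound 2 gives 73500 nM. Compound 3 gives > 100000 nM, which is a limit of this assay rather than a number. Compound 1 likewise gives > 100000 nM, a limit. Compound 3 therefore stands at the weak end of what this assay can report, a position shared by two of the three values here, as the limit of > 100000 nM in this assay, at which 2 of the 3 values shown sit, records.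

Compound 4 `O=C(Nc1ccc(Cl)c(-c2nnc3c(Cl)cccn23)c1)c1ccc(Cl)cc1Cl` differs from compound 3 by chloro in place of hydrogen on an aromatic carbon, so that 2-chlorophenyl becomes 2,4-dichlorophenyl. Among the compounds with values here, the one measured step of the same kind, an at least 1.3-fold higher number from compound 2 to compound 3 (0.13 log units; that floor lies within the scatter), moved the number to the limit, by an amount whose floor lies within the scatter. Compound 4 is expected to stay at or beyond that limit, with a step that the limit leaves unreadable from compound 3 to compound 4 not resolvable as a real step because compound 3 already reads > 100000 nM. Compound 4 is estimated at 120000 nM, between 50000 nM and 300000 nM, most likely reported only as a limit.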

Compound 4, half-maximal inhibitory concentration: > 100000 nM
Compound 4 was reported as a limit (the forecaster's own chance of this, stated with the estimate: 75%); the middle value does not contradict the limit.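

The change from 2-chlorophenyl to 2,4-dichlorophenyl cannot be read as a step in this assay, as compound 3 and compound 4 both stand at a limit of the assay. Against the unsubstituted phenyl of compound 2, the only reading is an at least 1.3-fold higher number from compound 2 to compound 4 (0.13 log units; that floor lies within the scatter), so even this two-chloro ring is not shown to differ from phenyl beyond the scatter. Compound 2 remains alone in giving a number, and the added compound joins the others at one mark: the limit of > 100000 nM in this assay, at which 3 of the 4 values shown sit.

The substituted rings shown carry only chloro, fluoro and trifluoromethyl groups, so what an amine, a methoxy group or a carboxylic acid on this ring would do in this assay stays open. As far as these compounds go, how far compound 3 and compound 4 lie past the limit also stays open.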